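This account rests on a few compounds, and the source may have more. Where it says the series, first, only, none or still open, it means among the compounds named here.

Series notes. Compound 1 `O=S(=O)(Nc1ccc(-c2nc3ccccc3o2)cc1)c1ccccc1Cl` carries a 2-chlorophenyl group on the sulfonyl sulfur of the shared core. In an assay on isolated protein for inhibition of malate dehydrogenase, mitochondrial (Sus scrofa), with stated times of 45 min and 30 min (a higher number here means a weaker inhibitor, a lower number a stronger inhibitor), compound 1 gives only a limit, > 63000 nM. Compound 2 `Cc1ccccc1S(=O)(=O)Nc1ccc2oc(-c3ccccc3)nc2c1` also reaches only a limit in this assay, > 63000 nM. Compound 3 `C=Cc1ccc(S(=O)(=O)Nc2ccc3oc(-c4ccccc4)nc3c2)cc1` likewise stops at a limit in this assay, > 63000 nM. For the measured compounds named here, the one measured step, a step that the two limits leave unreadable from compound 2 to compound 3, is accordingly unreadable in size and direction. Going by the values given here, compound 1 stands, like the other two, at the limit of > 63000 nM in this assay, at which 3 of the 3 values shown sit, and no measured compound in this assay has a number.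

Compound 4 `O=S(=O)(Nc1ccc(-c2nc3ccccc3o2)cc1)c1cccs1` differs from compound 1 in one place: thiophen-2-yl in place of 2-chlorophenyl on a sulfonyl sulfur. Among the compounds with values here, no measured step changes the group on the sulfonyl sulfur against a readable value, and the only step among the measured compounds, a step that the two limits leave unreadable from compound 2 to compound 3, is itself bounded by two limits. Nothing measured supports an expectation of a step beyond the scatter in this assay, in either direction, and nothing argues against one. Compound 4 is expected to give about 100000 nM, with a range from 30000 nM to 500000 nM, and most likely to return only a limit again. The estimated step that the limit leaves unreadable from compound 1 to compound 4 is thus expected to be none that can be read.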

Compound 4, half-maximal inhibitory concentration: > 63000 nM
Compound 4 ended at the assay's limit; the forecaster's own chance of this, stated with the estimate: 85%; the middle value is on the limit's open side.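

No step can be read from compound 1 to compound 4, since each gives only a limit in this assay and the whole series sits at the same one: the limit of > 63000 nM in this assay, at which 4 of the 4 values shown sit.

The compounds shown leave open whether any group on the sulfonyl sulfur gives a number in this assay at all, and how thiophen-2-yl and 2-chlorophenyl compare.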